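A few compounds are considered here, and "the series" means these few. Any claim that something is new, unique, unknown or untested is made for them only; others in the source may bear on it.

Three analogues of the shared core have been run in an assay for inhibition of transmembrane protease serine 4 (Homo sapiens), read by fluorescence; a lower number here means a stronger inhibitor, a higher number a weaker inhibitor. Among the measured compounds shown here, compound 1 `O=C(Nc1cc(C(F)(F)F)cc(C(F)(F)F)c1)c1cc(F)ccc1O` gives 29000 nM, and compound 2 `COc1ccc(O)c(C(=O)Nc2cc(C(F)(F)F)cc(C(F)(F)F)c2)c1` gives 29000 nM; the one single-change step measured so far, no change at the digits printed from compound 1 to compound 2 (within the scatter), produced nothing beyond the scatter. Compound 3 `O=C(Nc1cc(Cl)cc(Cl)c1)c1cc(Cl)ccc1O` gives 19000 nM. Its number is the lowest of the three, but it sits within the scatter of both compound 1 and compound 2, so no order among the three compounds can be claimed and none of them can be called the strongest.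

Compound 4 `O=C(Nc1cc(Cl)c(Cl)c(Cl)c1)c1cc(Cl)ccc1O` has not yet been measured. It differs from compound 3 by chloro in place of hydrogen on an aromatic carbon. For the measured compounds named here, no measured step involves a chloro entering in place of hydrogen; the only measured step exchanges methoxy for fluoro and was flat. With nothing that bears directly on the change, the expectation rests on how flat the series has been so far: the three numbers lie within the scatter of one another, so for compound 4 the step of a 1.3-fold lower number from compound 3 to compound 4 (0.10 log units; within the scatter) is expected to stay within the scatter, in no firm direction. Compound 4 is therefore estimated at 15000 nM, with a range from 6000 nM to 40000 nM.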

Compound 4, half-maximal inhibitory concentration: > 100000 nM
Compound 4 was reported as a limit; the forecaster's own chance of this, stated with the estimate: 15%; middle value at least 6.6-fold (0.82 log units) away from the limit.
By their numbers in this assay, from the lowest: compounds 3, 1 and 2 (each within the scatter of the next). At a limit, above all of these: compound 4.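

Chloro in place of hydrogen on this aromatic carbon gives the first step in the series beyond the scatter, an at least 5.2-fold higher number from compound 3 to compound 4 (0.72 log units; beyond the scatter), whereas the only earlier step, no change at the digits printed from compound 1 to compound 2 (within the scatter), was flat. In this assay compound 4 gives > 100000 nM, which is a limit of the assay and not a number. The flatness of the first three compounds therefore does not extend to this position, ortho to two chloro groups and para to a large group, where hydrogen and chloro are clearly not interchangeable, and the true size of the step remains unknown, with the series reaching the top of its readable range only here: the limit of > 100000 nM in this assay, at which 1 of the 4 values shown sits.

The compounds shown leave open whether the step belongs to chloro specifically or would also appear with another group on this carbon, such as an amine or a carboxylic acid. They also leave open whether the same chloro would give the same step on a ring where this carbon is not ortho to two chloro groups.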